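Sulfonamide-Bearing Arm in Place of Bromophenyl

A few compounds are considered here, and "the series" means these few. Any claim that something is new, unique, unknown or untested is made for them only; others in the source may bear on it.

Measured compounds:
compound 1 `O=C1O[C@H]([C@@H](O)Cn2cc(-c3ccc(Br)cc3)nn2)C(OCc2ccccc2)=C1OCc1ccccc1` — 5070 nM
compound 2 `COc1ccccc1-c1cn(C[C@H](O)[C@H]2OC(=O)C(OCc3ccccc3)=C2OCc2ccccc2)nn1` — > 100000 nM
compound 3 `O=C1O[C@H]([C@@H](O)Cn2cc(-c3cc(F)cc(F)c3)nn2)C(OCc2ccccc2)=C1OCc1ccccc1` — 11600 nM

In a functional assay on HepG2 cells (Homo sapiens) for antiproliferative activity, read by MTT assay, with a stated time of 72 h (a lower number here means a stronger inhibitor, a higher number a weaker inhibitor), compound 1 gives 5070 nM, the lowest of the two numbers shown. Compound 3 gives 11600 nM in this assay. For compound 2 this assay reports only a limit, > 100000 nM (the limit of > 100000 nM in this assay, at which 1 of the 3 values shown sits).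

Compound 4 `Cc1ccc(S(=O)(=O)NCc2cn(C[C@H](O)[C@H]3OC(=O)C(OCc4ccccc4)=C3OCc3ccccc3)nn2)cc1` is the next compound, not yet measured in this assay. Relative to compound 1 the change is (((4-methylphenyl)sulfonyl)amino)methyl in place of 4-bromophenyl on an aromatic carbon.

Two measured steps start from compound 1 and alter the same group at the same place. Replacing the group gave a 2.3-fold higher number from compound 1 to compound 3 (0.36 log units; beyond the scatter), and gave an at least 19-fold higher number from compound 1 to compound 2 (1.29 log units; beyond the scatter), the latter reaching only a limit. Neither step introduces a group resembling the one entering in compound 4, so they bear on the step only in showing that this place has not tolerated change without loss in the compounds shown.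

Compound 4 is therefore expected to give a weaker result than compound 1, by an estimated 5.9-fold higher number from compound 1 to compound 4 (0.77 log units; beyond the scatter). The estimate for compound 4 in this assay is 30000 nM, with a range from 8000 nM to 150000 nM, and a real chance that only a limit is reported.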

Compound 4, half-maximal inhibitory concentration: 24900 nM
Compound 4: middle estimate off by 1.2-fold (0.08 log units), on the high side; the range from low to high includes it.
By their numbers in this assay, from the lowest: compound 1; then compound 3; then compound 4. At a limit, above all of these: compound 2.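

In this assay, among these compounds, every earlier group at this place on the five-membered aromatic ring was a substituted phenyl, and the (((4-methylphenyl)sulfonyl)amino)methyl arm is the first of a different kind, bringing a hydrogen-bond donor and acceptors that 4-bromophenyl lacks, with a 4.9-fold higher number from compound 1 to compound 4 (0.69 log units; beyond the scatter). This change therefore also loses activity, which leaves 4-bromophenyl with the lowest number among the compounds shown, yet the arm does not sit far from the substituted phenyls, since the step from the 3,5-difluorophenyl compound is only modest, with a 2.1-fold higher number from compound 3 to compound 4 (0.33 log units; beyond the scatter). The 2-methoxyphenyl group does worse than the arm, with an at least 4.0-fold lower number from compound 2 to compound 4 (0.60 log units; beyond the scatter), a step that rests on a limit and not on a number: the limit of > 100000 nM in this assay, at which 1 of the 4 values shown sits.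

The compounds shown leave open which part of the arm sets its value, the sulfonyl, the amino hydrogen, the methyl-bearing phenyl or the connecting methylene. A plain aminomethyl group, a carboxamide in place of the sulfonyl, or a 4-bromophenyl carried on the same sulfonylamino arm would begin to separate these parts.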